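The source may hold more compounds than are shown below. What is called first, only, known or untested is meant among the compounds shown, and "the series" means these compounds.

The measured compounds and what they show:

Compound 1 `COc1ccc(-c2cc(=O)c3c(OC)cc(OC)cc3n2S(=O)(=O)c2cccc([N+](=O)[O-])c2)cc1`: in a functional assay on HepG2 cells (Homo sapiens) for antiproliferative activity, with a stated time of 72 h (on this read-out lower numbers stand for an effect already at smaller amounts and higher numbers for an effect only at larger amounts of compound), compound 1 gives > 39600 nM, which is a limit of the assay and not a number.
Compound 2 `COc1ccc(-c2cc(=O)c3c(OC)cc(OC)cc3n2S(=O)(=O)c2ccc(C#N)cc2)cc1`: in this assay compound 2 gives > 17200 nM, again a limit rather than a number.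
Compound 3 `COc1ccc(-c2cc(=O)c3c(OC)cc(OC)cc3n2S(=O)(=O)c2cc(Cl)cc(Cl)c2O)cc1`: in this assay compound 3 gives > 37900 nM, also a limit and not a number.

So compound 3 stands nowhere in particular on a scale: its value is only the limit (the limit of > 37900 nM in this assay, at which 1 of the 3 values shown sits), and the two other compounds likewise sit at limits, the limit of > 17200 nM in this assay, at which 1 of the 3 values shown sits, and (the limit of > 39600 nM in this assay, at which 1 of the 3 values shown sits). The steps between them are accordingly unreadable: a step that the two limits leave unreadable from compound 1 to compound 2, a step that the two limits leave unreadable from compound 1 to compound 3 and a step that the two limits leave unreadable from compound 2 to compound 3.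

Compound 4 `COc1ccc(-c2cc(=O)c3c(OC)cc(OC)cc3n2S(=O)(=O)Cc2ccccc2)cc1` differs from compound 3 in one place: benzyl in place of 3,5-dichloro-2-hydroxyphenyl on a sulfonyl sulfur. Within the data shown here, the only measured steps that bear on a change at this sulfonyl sulfur are the three unreadable ones above, so no size of step in this assay can be taken from them, in either direction. What the three compounds share is that none showed an effect within the tested range, and compound 4, which keeps the same core, is expected to behave the same way. The step from compound 3 to compound 4 is therefore expected to be a step that the limit leaves unreadable from compound 3 to compound 4, nothing beyond the scatter. For compound 4 the estimate in this assay is 40000 nM, with a range from 8000 nM to 150000 nM, most likely reported again only as a limit.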

Compound 4, half-maximal effective concentration: > 34400 nM
Compound 4 gave a limit, no number; the forecaster's own chance of this, stated with the estimate: 80%; the middle value does not contradict the limit.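

Like compound 1, compound 2 and compound 3, compound 4 gives only a limit and not a number in this assay, and the steps from each of the first three to compound 4 cannot be read. The compounds shown leave open whether any group on the sulfonyl sulfur produces a measurable effect in this assay, and how large any difference between these groups would be.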